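Homologating the ester chain of a pyridinyl thiourea

A few compounds are considered here, and "the series" means these few. Any claim that something is new, unique, unknown or untested is made for them only; others in the source may bear on it.

Measured compounds:
compound 1 `CCOC(=O)CC/N=C(\S)Nc1ccccn1` with 18%
compound 2 `COC(=O)C/N=C(\S)Nc1ccc(Cl)cn1` with 74.6%

Both compounds were tested in an assay on isolated protein for inhibition of glucose-6-phosphatase catalytic subunit 1 (Rattus norvegicus), tested at 100 uM; on this read-out higher numbers stand for more inhibition at the one concentration tested (going by the name of the read-out) and lower numbers for less inhibition. Compound 2 stands highest of the two numbers measured, and in this assay compound 2 gives 74.6% while compound 1 gives 18%, a gap that is beyond the scatter of this kind of measurement; the two structures differ in more than one place, so nothing more is drawn from that pair. Compound 3 `CCOC(=O)CC/N=C(\S)Nc1ccc(Cl)cn1` has not been measured yet. It differs from compound 2 in one place: (ethoxycarbonyl)methyl in place of methoxycarbonyl on a saturated chain carbon bound to a double-bonded nitrogen. The chlorine on the ring of compound 2 is kept. Among the compounds with values here, no measured pair shows this change alone, so its size is open. A modest decrease in this assay is expected, at the edge of the scatter rather than clearly beyond it. Compound 3 is estimated at 60%, with a range from 30% to 85%, which means an expected step of a number 14.6 percentage points lower from compound 2 to compound 3 (beyond the scatter).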

Compound 3, a percentage reported as inhibition, at one concentration (the size of the read-out at that concentration, not a potency): 54.4%
Beside the measured number, compound 3's estimate is 5.6 percentage points above it; the range from low to high includes it.
By their numbers in this assay, from the lowest: compound 1; then compound 3; then compound 2.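

In this assay, putting (ethoxycarbonyl)methyl in place of methoxycarbonyl on a saturated chain carbon bound to a double-bonded nitrogen, with the chlorine kept, gives a number 20.2 percentage points lower from compound 2 to compound 3 (beyond the scatter), so this change alone reduces inhibition at the one concentration tested. With that (ethoxycarbonyl)methyl group held constant, chloro in place of hydrogen on an aromatic carbon gives a number 36.4 percentage points higher from compound 1 to compound 3 (beyond the scatter), so the ring change raises inhibition on its own. Within the data shown here, compound 3 thus links two compounds that differ in more than one place, giving each single change a size of its own, although each size comes from only one pair.

From the compounds shown here alone, whether a carboxylic acid or an amide in place of the ester, or a still longer chain, would retain inhibition stays open. Nothing available here explains why either step occurs.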